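Dropping the 3-methylbut-2-en-1-yl group from compound 2

This account rests on a few compounds, and the source may have more. Where it says the series, first, only, none or still open, it means among the compounds named here.

In a functional assay on MCF7 cells (Homo sapiens) for antiproliferative activity (on this read-out higher numbers stand for weaker inhibition and lower numbers for stronger inhibition), compound 2 (`CC(C)=CCc1cccc(C(=O)Nc2cc3ccc(OC4CCN(C)CC4)c(C)c3oc2=O)c1`) gives 2100 nM and compound 1 (`CC(=O)Oc1ccc(C(=O)Nc2cc3ccc(OC4CCN(C)CC4)c(C)c3oc2=O)cc1`) gives 1620 nM, so the two stand level within the scatter. Compound 3 (`Cc1c(OC2CCN(C)CC2)ccc2cc(NC(=O)c3ccccc3)c(=O)oc12`) carries hydrogen in place of 3-methylbut-2-en-1-yl on an aromatic carbon. Within the data shown here, the only measured step bearing on this, a 1.3-fold higher number from compound 1 to compound 2 (0.11 log units; within the scatter), changes the same aryl group and stays within the scatter. It is thin evidence, but no shift beyond the scatter is expected in this assay. The expected step is a 1.1-fold lower number from compound 2 to compound 3 (0.04 log units; within the scatter). For compound 3 the estimate is 1900 nM, with a range of 800 nM to 4500 nM.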

Compound 3, half-maximal inhibitory concentration: 11700 nM
For compound 3 the middle estimate is 6.2-fold (0.79 log units) below the measured one; the whole stated range lies below it.
By their numbers in this assay, from the lowest: compounds 1 and 2 (each within the scatter of the next); then compound 3.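

Taking 3-methylbut-2-en-1-yl off is not a neutral change in this assay (a 5.6-fold higher number from compound 2 to compound 3 (0.75 log units; beyond the scatter)), and taking off acetoxy goes the same way (a 7.2-fold higher number from compound 1 to compound 3 (0.86 log units; beyond the scatter)). Across these three compounds, the two substituted aryl groups stand level within the scatter, while plain phenyl gives the weakest inhibition. No measurement shown here accounts for the gap.

As far as these compounds go, whether a methyl, an amine or a carboxylic acid on this ring would also keep the lower numbers remains open. The effect of the substituent's place on the ring, apart from its identity, is also unresolved.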